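The compounds below may be only part of what the source reports. "The series", "measured", "known", "first", "only" and "open" are said of these compounds alone.

In an assay on membranes from HEK293 cells for displacement of a labelled ligand from adenosine receptor A2b (Homo sapiens), read by scintillation counting, with a stated time of 30 min, tested at 1 uM (a higher number here means more inhibition at the concentration tested (going by the name of the read-out), a lower number less inhibition), two compounds of the shared core have been measured so far. Compound 1 `CCCOC(=O)C1=C(C)NC(=S)NC1c1ccco1` gives 46% in this assay. Compound 2 `COC(=O)C1=C(C)NC(=S)NC1c1ccoc1` gives 48% in this assay. These two values sit within the usual scatter of each other, so compound 2 cannot be ranked above or below compound 1 on the numbers shown; compound 1 also differs from compound 2 in more than one place, and no single-change step between measured compounds is available to lean on.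

The next compound, compound 3 `CCCOC(=O)C1=C(C)NC(=S)NC1c1ccoc1`, has not yet been measured in this assay. Its difference from compound 2 is counted as ethyl in place of hydrogen on a saturated chain carbon bound to an oxygen next to a carbonyl group. Within the data shown here, since the one measured compound that carries the propoxycarbonyl group, compound 1, returns a value within the scatter of compound 2, the step from compound 2 to compound 3 is expected to be none beyond the scatter, giving an estimated no change at the digits printed from compound 2 to compound 3 (within the scatter). On that basis compound 3 is estimated to give 48% in this assay, with a range from 35% to 60%.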

Compound 3, a percentage reported as inhibition, at one concentration (the size of the read-out at that concentration, not a potency): 45%
Estimate against measurement, compound 3: 3 percentage points above; measured number inside the range.
By their numbers in this assay, from the lowest: compounds 3, 1 and 2 (each within the scatter of the next).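

In this assay, among these compounds, the pair of compound 2 and compound 3 gives the first single-change reading at this position: ethyl in place of hydrogen on a saturated chain carbon bound to an oxygen next to a carbonyl group, which is methoxycarbonyl to propoxycarbonyl, amounts to a number 3 percentage points lower from compound 2 to compound 3 (within the scatter) with furan-3-yl held in place. The other new pair keeps the propoxycarbonyl group and changes only the ring substituent, furan-3-yl in place of furan-2-yl on a saturated ring carbon, and reads a number 1 percentage points lower from compound 1 to compound 3 (within the scatter) in this case, so neither single change separates the compounds in this assay on these numbers. No accompanying measurement offers an explanation for these results.

The compounds shown leave open whether a longer chain such as hexyl, or a benzyl group, on the ester oxygen would stay within the scatter of these values, and whether an amide or a carboxylic acid in place of the ester would do the same. They also leave open whether a phenyl group in place of the furan ring would move the number beyond the scatter, and readings at a single concentration leave potency itself undefined.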